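Amino acid for methoxy on a quinone-type core

The source may report more compounds than this note shows. Statements on the series, on what has been measured and on what is new or still open speak of the compounds shown alone.

Going by the values given here, compound 1 `C=C1[C@H](C)CCC[C@]1(C)CC/C(C)=C/CC1=C(O)C(=O)C=C(OC)C1=O` gives 2.4 ug/mL in an ADME assay on L1210 cells (Mus musculus) for cytotoxicity, with a stated time of 48 h (on this read-out higher numbers stand for weaker inhibition and lower numbers for stronger inhibition), the only number in the set. Compound 2 `CC1=CCC[C@](C)(CC/C(C)=C/CC2=C(O)C(=O)C=C(N[C@H](CO)C(=O)O)C2=O)[C@@H]1C` reaches only the limit > 10 ug/mL, a limit of this assay rather than a number, (the limit of > 10 ug/mL in this assay, at which 1 of the 2 values shown sits). Compound 3 `C=C1[C@H](C)CCC[C@]1(C)CC/C(C)=C/CC1=C(O)C(=O)C=C(NCC(=O)O)C1=O` differs from compound 1 by (carboxymethyl)amino in place of methoxy on a double-bonded ring carbon. Among the compounds with values here, no measured step of this kind exists here; the step of a 3.3-fold higher number from compound 1 to compound 3 (0.52 log units; beyond the scatter) is expected to be beyond the scatter and toward weaker inhibition. Compound 3 is estimated at 8 ug/mL, with a range from 3 ug/mL to 20 ug/mL, and the assay may report only a limit.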

Compound 3, half-maximal inhibitory concentration: 4 ug/mL
Estimate against measurement, compound 3: 2.0-fold (0.30 log units) above; low and high end bracket the measured number.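

In this assay the exchange on this double-bonded ring carbon gives a 1.7-fold higher number from compound 1 to compound 3 (0.22 log units; within the scatter) and so does not separate methoxy from (carboxymethyl)amino. On this core, the position therefore takes the larger group, which carries a carboxylic acid, without a step beyond the scatter. No measured property accounts for this step.

Compound 2 stands at a limit, not a number, and differs from compound 1 in more than one place, so no step can be read from it. Open, on these data alone, is how this assay reads a methylamino group without the carboxylic acid, or a longer chain ending in that acid.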